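The source may hold more compounds than are shown below. What is called first, only, known or untested is meant among the compounds shown, and "the series" means these compounds.

Measured in a functional assay on SH-SY5Y cells (Homo sapiens) for cytotoxicity, read by MTT assay; on this read-out lower numbers stand for stronger inhibition and higher numbers for weaker inhibition:
compound 1 `COC(=O)[C@]1(Cc2ccc(O)c(CC=C(C)C)c2)OC(=O)C(O)=C1c1ccc(OC)cc1`: < 10000 nM
compound 2 `COC(=O)[C@]1(Cc2ccc(O)c(CC=C(C)C)c2)OC(=O)C(O)=C1c1ccccc1`: < 10000 nM
compound 3 `COC(=O)[C@]1(Cc2ccc(OC)c(CC=C(C)C)c2)OC(=O)C(O)=C1c1ccccc1`: < 10000 nM

All three entries are limits, not numbers. Compound 1 has only a limit, and the series sits at the same place: the limit of < 10000 nM in this assay, at which 3 of the 3 values shown sit.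

Compound 4 `COC(=O)[C@]1(Cc2ccc(O)c(CC(C)=O)c2)OC(=O)C(O)=C1c1ccc(OC)cc1` departs from compound 1 in one place: acetyl in place of 2-methylprop-1-en-1-yl on a saturated chain carbon bound to an aromatic carbon. Two measured steps exist, a step that the two limits leave unreadable from compound 1 to compound 2 and a step that the two limits leave unreadable from compound 2 to compound 3. Neither touches this chain and neither has a readable size, so neither gives a size to carry over. No direction can be expected in this assay, and the estimated change is a step that the limit leaves unreadable from compound 1 to compound 4. Compound 4 is estimated at 5000 nM, in a range of 1500 nM to 10000 nM. For compound 4, this assay may again report only a limit.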

Compound 4, half-maximal inhibitory concentration: < 10000 nM
Compound 4 was reported as a limit; the forecaster's own chance of this, stated with the estimate: 80%; the middle value does not contradict the limit.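

Among these compounds, compound 1 and compound 4 both stand as limits in this assay, and no step between them can be read. The compounds shown leave open their actual potencies, their order, and what each change does: the limit of < 10000 nM in this assay, at which 4 of the 4 values shown sit.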